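Moving the nitro group around the thiourea aryl ring

This account rests on a few compounds, and the source may have more. Where it says the series, first, only, none or still open, it means among the compounds named here.

compound 1 `COc1cc2c(cc1OC)C(=O)C(CC1CCN(C(=S)Nc3ccc(C)cc3)CC1)C2` — 30 mg/kg
compound 2 `COc1cc2c(cc1OC)C(=O)C(CC1CCN(C(=S)Nc3ccccc3[N+](=O)[O-])CC1)C2` — 100 mg/kg

Of the compounds shown here, two have been measured in a functional assay on the whole organism (strain Swiss albino) with Mus musculus as the target, in the maximal electroshock model, with a stated time of 0.5 h; a higher number here means that more compound is needed for the effect, a lower number that less compound is needed. Compound 1 `COc1cc2c(cc1OC)C(=O)C(CC1CCN(C(=S)Nc3ccc(C)cc3)CC1)C2` gives 30 mg/kg, and compound 2 `COc1cc2c(cc1OC)C(=O)C(CC1CCN(C(=S)Nc3ccccc3[N+](=O)[O-])CC1)C2` gives 100 mg/kg, which is the highest of the two numbers; its nearest neighbour is compound 1, and the step is a 3.3-fold higher number from compound 1 to compound 2 (0.52 log units; beyond the scatter), a change of 2-nitrophenyl in place of 4-methylphenyl on an amide-type nitrogen.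

Compound 3 `COc1cc2c(cc1OC)C(=O)C(CC1CCN(C(=S)Nc3cccc([N+](=O)[O-])c3)CC1)C2` has not yet been measured. It differs from compound 2 in one place: 3-nitrophenyl in place of 2-nitrophenyl on an amide-type nitrogen. Going by the values given here, the only measured step, from compound 1 to compound 2, swaps the whole aryl group rather than relocating the nitro group, so it bears on this change only loosely; it shows that an exchange on this amide-type nitrogen can shift the number by a modest amount. For compound 3 the expected step is therefore a 1.7-fold lower number from compound 2 to compound 3 (0.22 log units; within the scatter), a modest movement toward a lower number, with the outcome possibly staying within the scatter. Compound 3 is estimated at 60 mg/kg in this assay, with a range from 30 mg/kg to 150 mg/kg.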

Compound 3, minimum effective dose: 300 mg/kg
Compound 3: middle estimate off by 5.0-fold (0.70 log units), on the low side; measured number outside the range, above it.
By their numbers in this assay, from the lowest: compound 1; then compound 2; then compound 3.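

In this assay, the new result shows that the place of the nitro group on the aryl ring matters on its own: the two groups hold the same atoms joined differently, yet 3-nitrophenyl in place of 2-nitrophenyl on the amide-type nitrogen gives a 3.0-fold higher number from compound 2 to compound 3 (0.48 log units; beyond the scatter) and so moves the number upward, beyond the scatter. Set against the 4-methylphenyl group, the same 3-nitrophenyl group gives a 10-fold higher number from compound 1 to compound 3 (1.00 log units; beyond the scatter) as the widest gap among the three compounds, which places compound 1 lowest and compound 3 highest, with compound 2 in the middle. Nothing available here explains why relocating the nitro group shifts the number in this way.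

The compounds shown leave open where 4-nitrophenyl would fall relative to the 2-nitrophenyl and 3-nitrophenyl groups, and thus how the full set of nitro placements would rank. They also leave open whether an unsubstituted phenyl, a 4-methoxyphenyl or a 4-aminophenyl group would stay near compound 1, and whether a urea carbonyl in place of the thiocarbonyl would preserve this order.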